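The compounds below may be only part of what the source reports. "The series", "measured", "known", "first", "only" and "open" are said of these compounds alone.

Measured compounds in the series:
Compound 1 `CC(C)CSc1nc(N)nc2c1ncn2/C=C1/CC1(CO)CO`: in an ADME assay on BCBL1 cells (Homo sapiens) for cytotoxicity, with a stated time of 7 days (on this read-out higher numbers stand for lower toxicity in this test and lower numbers for higher toxicity in this test), compound 1 gives > 20000 nM, which is a limit of the assay and not a number.
Compound 2 `Nc1nc(NC2CCCC2)c2ncn(/C=C3/CC3(CO)CO)c2n1`: in this assay compound 2 gives 71700 nM.
Compound 3 `CCCCCCSc1nc(N)nc2c1ncn2/C=C1/CC1(CO)CO`: in this assay compound 3 gives > 20000 nM, again a limit of the assay rather than a number.

Compound 3 thus stands at a limit only, and it shares that position with one other value (the limit of > 20000 nM in this assay, at which 2 of the 3 values shown sit). The steps that lead to it are not readable: a step that the two limits leave unreadable from compound 1 to compound 3, and a step that the limit leaves unreadable from compound 2 to compound 3; nor is a step that the limit leaves unreadable from compound 1 to compound 2. For the measured compounds named here, no readable step size exists within this set, so no precedent can be sized.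

The next compound is compound 4 `Nc1nc(SCc2ccccc2)c2ncn(/C=C3/CC3(CO)CO)c2n1`, which differs from compound 3 by phenyl in place of pentyl on a saturated chain carbon bound to a sulfur. Going by the values given here, the only step at the saturated chain carbon bound to a sulfur was itself unreadable, so nothing here points to a change beyond the scatter. Compound 4 is therefore expected to show a step that the limit leaves unreadable from compound 3 to compound 4, most likely none that can be read. Compound 4 is estimated at 30000 nM, with a range from 8000 nM to 110000 nM, and a limit is the more probable outcome.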

Compound 4, half-maximal cytotoxic concentration: > 20000 nM
Compound 4: only a limit was reported; the forecaster's own chance of this, stated with the estimate: 60%; the middle value lies beyond the limit too.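

In this assay, for the compounds shown here, compound 4 gives > 20000 nM, a limit of the assay and not a number, so no step from compound 1, compound 2 or compound 3 to compound 4 can be read. Left open is whether compound 1, compound 3 and compound 4 differ from one another or from compound 2 in this assay.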